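Swapping the dichlorophenyl group for a pyrrole

The source may report more compounds than this note shows. Statements on the series, on what has been measured and on what is new or still open speak of the compounds shown alone.

compound 1 `CN1CCN(c2cccc(N/C=C3\C(=O)Nc4ccc(NC(=O)c5cccc(F)c5)cc43)c2)CC1` gives 6720 nM
compound 2 `CN1CCN(c2cccc(N/C=C3\C(=O)Nc4ccc(NC(=O)c5c(F)cccc5F)cc43)c2)CC1` gives 3030 nM
compound 3 `CN1CCN(c2cccc(N/C=C3\C(=O)Nc4ccc(NC(=O)c5c(Cl)cccc5Cl)cc43)c2)CC1` gives 2370 nM

All three numbers come from a functional assay on HepG2 cells (Homo sapiens) for inhibition, read by sulforhodamine B assay, with a stated time of 3 days; on this read-out higher numbers stand for weaker inhibition and lower numbers for stronger inhibition. Compound 3 sits at the low end of this small set, but it shares that end with another compound: a 1.3-fold lower number from compound 2 to compound 3 (0.11 log units; within the scatter). The gap to the remaining compound is clearer: a 2.8-fold lower number from compound 1 to compound 3 (0.45 log units; beyond the scatter), and similarly a 2.2-fold lower number from compound 1 to compound 2 (0.35 log units; beyond the scatter).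

The next change gives compound 4 `CN1CCN(c2cccc(N/C=C3\C(=O)Nc4ccc(NC(=O)c5ccc[nH]5)cc43)c2)CC1`, with 1H-pyrrol-2-yl in place of 2,6-dichlorophenyl on a carbonyl carbon. Among the measured compounds shown here, no measured step brings in a five-membered aromatic ring, so the evidence is indirect. The nearest guide is the set of steps at this same carbonyl carbon, which run from within the scatter to modest. Both 2,6-difluorophenyl and 2,6-dichlorophenyl gave lower numbers than the 3-fluorophenyl of compound 1, as a 2.8-fold lower number from compound 1 to compound 3 (0.45 log units; beyond the scatter) shows. Leaving 2,6-dichlorophenyl may therefore give back a similar amount, though three compounds make a thin basis. A modest rise in this assay is expected, estimated as a 2.1-fold higher number from compound 3 to compound 4 (0.32 log units; beyond the scatter). For compound 4 the estimated value is 5000 nM, with an expected range from 1700 nM to 15000 nM.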

Compound 4, half-maximal inhibitory concentration: 5370 nM
The estimate for compound 4 lay 1.1-fold (0.03 log units) below the measured number, within the range that was stated.
By their numbers in this assay, from the lowest: compounds 3, 2, 4 and 1 (each within the scatter of the next, the first and the last beyond it).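

In this assay, among the compounds shown here, compound 4 is the first of this set with a group on the carbonyl carbon that is not a substituted phenyl, and leaving 2,6-dichlorophenyl for 1H-pyrrol-2-yl costs a real but modest amount (a 2.3-fold higher number from compound 3 to compound 4 (0.36 log units; beyond the scatter)). The other two comparisons (a 1.8-fold higher number from compound 2 to compound 4 (0.25 log units; within the scatter) and a 1.3-fold lower number from compound 1 to compound 4 (0.10 log units; within the scatter)) both stay within the scatter, so the pyrrole cannot be told apart from either the 2,6-difluorophenyl or the 3-fluorophenyl group, even though those two phenyl groups differ from each other beyond the scatter. Replacing the six-membered carbon-only ring with a five-membered ring holding a hetero atom therefore moves the number no further than the earlier changes among the halogen-bearing phenyl groups did, and the position accepts this different ring without a large shift in either direction.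

No measurement of any property of these groups is at hand to explain these numbers. From the compounds shown here alone, it remains open whether the hydrogen on the ring nitrogen of the pyrrole matters, which a 1-methylpyrrol-2-yl group would help to test, and whether other five-membered rings, such as furan-2-yl or thiophen-2-yl, would land in the same range.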